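The compounds below may be only part of what the source reports. "The series", "measured", "known", "first", "only" and "open" are said of these compounds alone.

Measured so far:
Compound 1 `Cc1cn([C@@H]2O[C@H](CO[Si](C)(C)C(C)(C)C)[C@@]3(OS(=O)(=O)C(I)=C3N)[C@H]2O[Si](C)(C)C(C)(C)C)c(=O)n(C)c1=O`: 3900 nM
Compound 2 `Cc1cn([C@@H]2O[C@H](CO[Si](C)(C)C(C)(C)C)[C@@]3(OS(=O)(=O)C(I)=C3N)[C@H]2O[Si](C)(C)C(C)(C)C)c(=O)[nH]c1=O`: 4300 nM

Among the measured compounds shown here, in a functional assay on MT4 cells (Homo sapiens) for cytotoxicity (on this read-out lower numbers stand for higher toxicity in this test and higher numbers for lower toxicity in this test), compound 1 gives 3900 nM and stands level with compound 2, the only other compound measured. Compound 3 `Cc1cn([C@@H]2O[C@H](CO[Si](C)(C)C(C)(C)C)[C@@]3(OS(=O)(=O)C(c4ccsc4)=C3N)[C@H]2O[Si](C)(C)C(C)(C)C)c(=O)n(C)c1=O` has not been measured yet. Its structure differs from the core of compound 1 as follows: thiophen-3-yl in place of iodo on a double-bonded ring carbon. In short, thiophen-3-yl sits in place of iodo on a double-bonded ring carbon.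

For the measured compounds named here, only one measured step exists, a 1.1-fold higher number from compound 1 to compound 2 (0.04 log units; within the scatter). It puts hydrogen in place of methyl on an aromatic nitrogen, so it does not test the iodo group at all. The data therefore give no direction for this change, and a step beyond the scatter is not expected, though this remains uncertain. The estimated step is a 1.3-fold higher number from compound 1 to compound 3 (0.11 log units; within the scatter). Compound 3 is expected at 5000 nM, with an estimated range of 1800 nM to 20000 nM.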

Compound 3, half-maximal cytotoxic concentration: 3900 nM
For compound 3 the middle estimate is 1.3-fold (0.11 log units) above the measured one; measured number inside the range.
By their numbers in this assay, from the lowest: compounds 1, 3 and 2 (each within the scatter of the next).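

In this assay, putting thiophen-3-yl in place of iodo gives no change at the digits printed from compound 1 to compound 3 (within the scatter). Among the compounds shown here, this is the first reading at this double-bonded ring carbon, since the earlier pair differed only at an aromatic nitrogen, and it shows that a single iodine can give way to a five-membered aromatic ring without a step beyond the scatter. No supporting measurement is available to explain this result.

From the compounds shown here alone, whether the same holds for quite different groups at this carbon, such as an amine, a carboxylic acid or a longer alkyl chain, remains open. Going by these compounds, it is also open whether thiophen-3-yl would give a similar number with hydrogen in place of methyl on the aromatic nitrogen, as in compound 2.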